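This account rests on a few compounds, and the source may have more. Where it says the series, first, only, none or still open, it means among the compounds named here.

Three compounds share one core and differ in the group carried by the amide carbonyl. Compound 1, `O=C(/C=C/c1ccc([N+](=O)[O-])cc1)Nc1cc(Sc2ncn[nH]2)c(O)c2ccccc12`, gives 40.6% in an assay on isolated protein for inhibition of RAC-alpha serine/threonine-protein kinase (Homo sapiens), read by fluorescence, with a stated time of 30 min, tested at 10 uM; a higher number here means more inhibition at the concentration tested (going by the name of the read-out), a lower number less inhibition. Compound 2, `O=C(Nc1cc(Sc2ncn[nH]2)c(O)c2ccccc12)c1cccc([N+](=O)[O-])c1`, gives 29.3% in this assay, which places it second highest of the three numbers: its value sits within the usual scatter of that of compound 3, `O=C(Nc1cc(Sc2ncnc3nc[nH]c23)c(O)c2ccccc12)c1ccc(Cl)cc1`, which gives 21.7%, while compound 1 lies beyond the scatter above it. The three compounds differ from one another in more than one place. None of these gaps can be tied to a single change.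

Compound 4, `O=C(/C=C/c1ccccc1)Nc1cc(Sc2ncn[nH]2)c(O)c2ccccc12`, has not yet been measured. It differs from compound 2 in one place: 2-phenylethenyl in place of 3-nitrophenyl on a carbonyl carbon. Among the measured compounds shown here, there is no measured pair showing this exchange on its own, so its effect is uncertain. Given that compound 1, which also carries a phenylethenyl group, gives 40.6%, a modest rise from compound 2 is expected, of about a number 5.7 percentage points higher from compound 2 to compound 4 (within the scatter). Compound 4 is therefore estimated to give 35%, within a range from 20% to 50%.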

Compound 4, a percentage reported as inhibition, at one concentration (the size of the read-out at that concentration, not a potency): 26.2%
For compound 4 the middle estimate is 8.8 percentage points above the measured one; the range from low to high includes it.
By their numbers in this assay, from the lowest: compounds 3, 4 and 2 (each within the scatter of the next); then compound 1.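

In this assay, among the compounds shown here, hydrogen in place of nitro on an aromatic carbon gives a number 14.4 percentage points lower from compound 1 to compound 4 (beyond the scatter) and is the first single change in this set that lies beyond the scatter, so the nitro group on the phenylethenyl ring counts for something here. By contrast, 2-phenylethenyl in place of 3-nitrophenyl on a carbonyl carbon gives a number 3.1 percentage points lower from compound 2 to compound 4 (within the scatter) and so shows no readable effect of this exchange on its own. Nothing measured here gives a reason for either result.

The compounds shown leave open whether the gain depends on the nitro group itself or would also appear with another group in its place, such as an amine, a nitrile or a carboxylic acid. They also leave open whether removing the nitro group from compound 2 would have a similar effect.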